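A thiophene swap carried from one linker length to another

The source may report more compounds than this note shows. Statements on the series, on what has been measured and on what is new or still open speak of the compounds shown alone.

Of the compounds shown here, three sharing a common core have been measured in a functional assay on THP-1 cells (Homo sapiens) for inhibition, read by sulforhodamine B assay, with a stated time of 48 h, tested at 50 uM; a lower number here means less inhibition of growth, a higher number more inhibition of growth at the concentration tested. Compound 3 `COc1cccc(/C=C/C(=O)/C=C/c2ccc(OCc3cn(CCOc4cc(=O)oc5ccccc45)nn3)c(OC)c2)c1` gives 77%. Compound 1 `COc1cc(/C=C/C(=O)/C=C/c2cccs2)ccc1OCc1cn(CCOc2cc(=O)oc3ccccc23)nn1` differs from compound 3 only by thiophen-2-yl in place of 3-methoxyphenyl on a double-bonded chain carbon bound to a double-bonded chain carbon, and in this assay compound 1 gives 76%. The resulting step, a number 1 percentage points lower from compound 3 to compound 1 (within the scatter), shows that this exchange left the read-out essentially where it was. Compound 2 `COc1cccc(/C=C/C(=O)/C=C/c2ccc(OCc3cn(CCCCCOc4cc(=O)oc5ccccc45)nn3)c(OC)c2)c1` carries the same 3-methoxyphenyl group as compound 3 but sits on a different core; the difference between the two cores is not broken down here. In this assay compound 2 gives 37%, the lowest of the three numbers, and its distance from compound 1 and from compound 3 lies beyond the scatter.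

Compound 4 `COc1cc(/C=C/C(=O)/C=C/c2cccs2)ccc1OCc1cn(CCCCCOc2cc(=O)oc3ccccc23)nn1` has not yet been measured. It stands to compound 2 exactly as compound 1 stands to compound 3: the change is thiophen-2-yl in place of 3-methoxyphenyl on a double-bonded chain carbon bound to a double-bonded chain carbon, at the same place described in the same words, so it is the same change, occurring twice among these compounds. Going by the values given here, with only one earlier instance to draw on, the expectation is that the second instance behaves like the first. For compound 4 the expected step is no change at the digits printed from compound 2 to compound 4 (within the scatter), resting on the earlier step of a number 1 percentage points lower from compound 3 to compound 1 (within the scatter). Compound 4 is therefore estimated to give about 37% in this assay, most likely between 22% and 52%.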

Compound 4, percent growth inhibition at one concentration: 34%
The estimate for compound 4 lay 3 percentage points above the measured number, within the range that was stated.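

In this assay, the exchange of 3-methoxyphenyl for thiophen-2-yl on the second core came out as a number 3 percentage points lower from compound 2 to compound 4 (within the scatter), so the read-out again stayed essentially where it was even though this core starts from a much lower number. Set beside the earlier instance, the two steps agree: the same change on two cores in this assay, a number 1 percentage points lower (within the scatter) from compound 3 to compound 1 and a number 3 percentage points lower (within the scatter) from compound 2 to compound 4, 2 percentage points apart, within the scatter of two such steps. This shows that, across the two cores available here, the exchange carried over without a detectable change in growth inhibition at the single concentration tested, but it does not show that the same would hold on any further core, in another cell line, or in a full concentration series, and two instances are too few to establish a general rule for the series.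

The compounds shown leave open whether the exchange would remain just as silent on a core with a butylene chain, which would test the agreement on a further chain. They also leave open whether a furan-2-yl or pyridin-3-yl group, placed on the same double-bonded chain carbon bound to a double-bonded chain carbon, would behave as thiophen-2-yl does on these two cores.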